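Cyano for Fluoro on the Aryl Ring of Compound 3

The source may report more compounds than this note shows. Statements on the series, on what has been measured and on what is new or still open speak of the compounds shown alone.

Of the compounds shown here, three sharing one core have been tested in a functional assay on Caco-2 cells (Homo sapiens) for cytotoxicity, with a stated time of 48 h; on this read-out lower numbers stand for stronger inhibition and higher numbers for weaker inhibition. Compound 1 `O=[N+]([O-])c1ccc(CN2CCC(n3cc(CC(OCc4cc(-c5ccc(Br)cc5)no4)c4ccc(Br)cc4)nn3)CC2)cc1` gives 3000 nM. Compound 2 `O=[N+]([O-])c1ccc(CN2CCC(n3cc(CC(OCc4cc(-c5ccc(F)cc5)no4)c4ccc(Br)cc4)nn3)CC2)cc1` gives 3000 nM. Compound 3 `O=[N+]([O-])c1ccc(CN2CCC(n3cc(CC(OCc4cc(-c5cccc(F)c5)no4)c4ccc(Br)cc4)nn3)CC2)cc1` gives 5000 nM. The steps of no change at the digits printed from compound 1 to compound 2 (within the scatter) and a 1.7-fold higher number from compound 2 to compound 3 (0.22 log units; within the scatter), and likewise a 1.7-fold higher number from compound 1 to compound 3 (0.22 log units; within the scatter), all fall within the scatter, so the three numbers cannot be told apart with confidence, and compound 3 stands among them rather than apart from them.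

Compound 4 `N#Cc1cccc(-c2cc(COC(Cc3cn(C4CCN(Cc5ccc([N+](=O)[O-])cc5)CC4)nn3)c3ccc(Br)cc3)on2)c1` differs from compound 3 in a single place: cyano in place of fluoro on an aromatic carbon. Among the measured compounds shown here, none of the measured steps involves a cyano group; the nearest are the swaps of one halogen for another and the move of fluoro from one position to another, each within the scatter. With nothing in these data pointing to a shift, the expected step of no change at the digits printed from compound 3 to compound 4 (within the scatter) is none beyond the scatter. Compound 4 is therefore estimated at 5000 nM in this assay, with a range from 2000 nM to 12000 nM.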

Compound 4, half-maximal inhibitory concentration: 3000 nM
For compound 4 the middle estimate is 1.7-fold (0.22 log units) above the measured one; low and high end bracket the measured number.
By their numbers in this assay, from the lowest: compounds 1, 2, 4 and 3 (each within the scatter of the next).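

In this assay, cyano in place of fluoro on this aromatic carbon gives a 1.7-fold lower number from compound 3 to compound 4 (0.22 log units; within the scatter), so a group that is not a halogen can sit here without a change that can be told from the scatter. The larger swaps read the same way: 3-cyanophenyl in place of 4-fluorophenyl gives no change at the digits printed from compound 2 to compound 4 (within the scatter), and 3-cyanophenyl in place of 4-bromophenyl gives no change at the digits printed from compound 1 to compound 4 (within the scatter), so all four compounds remain one group on this read-out. No supporting data bear on why this result came out as it did.

Going by these compounds, it remains open whether an amine, a carboxylic acid or a longer alkyl chain on this ring would move the number beyond the scatter. On these data alone, the 4-cyanophenyl counterpart and a plain phenyl ring also remain open.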